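The source may report more compounds than this note shows. Statements on the series, on what has been measured and on what is new or still open speak of the compounds shown alone.

Measured so far:
compound 1, `COc1cc(OC)c(OC)cc1/C=C/C(=O)c1ccc(C)cc1` — 81100 nM
compound 2, `COc1cc(OC)c(OC)cc1/C=C/C(=O)c1cc(Cl)ccc1O` — > 150000 nM
compound 3, `COc1cc(OC)c(OC)cc1/C=C/C(=O)c1ccc(O)cc1O` — 32400 nM

In a functional assay on SW982 cells (Homo sapiens) for inhibition, read by MTT assay, with a stated time of 72 h (on this read-out lower numbers stand for stronger inhibition and higher numbers for weaker inhibition), compound 1 gives 81100 nM, the highest of the two numbers actually read. Compound 3 gives 32400 nM. Compound 2 reaches only a limit of the assay, > 150000 nM, as recorded in the limit of > 150000 nM in this assay, at which 1 of the 3 values shown sits. The steps among these three all exchange the whole ring on the carbonyl carbon: 2,4-dihydroxyphenyl in place of 4-methylphenyl brings a 2.5-fold lower number from compound 1 to compound 3 (0.40 log units; beyond the scatter), 5-chloro-2-hydroxyphenyl in place of 4-methylphenyl brings an at least 1.8-fold higher number from compound 1 to compound 2 (0.26 log units; that floor lies within the scatter), and 2,4-dihydroxyphenyl in place of 5-chloro-2-hydroxyphenyl brings an at least 4.6-fold lower number from compound 2 to compound 3 (0.66 log units; beyond the scatter).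

Compound 4, `COc1cc(OC)c(OC)cc1/C=C/C(=O)c1ccc([N+](=O)[O-])cc1`, keeps the shared core of compound 1 and differs from it by nitro in place of methyl on an aromatic carbon. For the measured compounds named here, no measured step changes a single group on that ring while leaving the rest in place, so none bears directly on this exchange; the whole-ring swaps seen so far moved the numbers only modestly, and in both directions. Compound 4 is therefore expected to stay close to compound 1, with a step of a 1.2-fold lower number from compound 1 to compound 4 (0.06 log units; within the scatter), not clearly beyond the scatter. The estimate for compound 4 in this assay is 70000 nM, with a range from 25000 nM to 200000 nM.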

Compound 4, half-maximal inhibitory concentration: > 150000 nM
Compound 4: a limit, no number (the forecaster's own chance of this, stated with the estimate: 20%); middle value at least 2.1-fold (0.33 log units) away from the limit.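

In this assay compound 4 gives > 150000 nM, which is a limit of the assay and not a number. Nitro in place of methyl, para to a large group, is the first exchange of a single group on this ring, whereas the earlier steps replaced the whole ring, and it brings an at least 1.8-fold higher number from compound 1 to compound 4 (0.26 log units; that floor lies within the scatter); the change therefore gives no gain over methyl at this position, although the floor of the step does not by itself separate the two compounds. The step cannot be sized any further, and compound 4 now joins compound 2 at the limit: the limit of > 150000 nM in this assay, at which 2 of the 4 values shown sit.

The compounds shown leave open how far the true value of compound 4 lies from that of compound 1, and so whether nitro truly weakens inhibition or merely matches methyl within the usual scatter. They also leave open what a different single group at this same position, such as an amine or a carboxylic acid, would do while the rest of compound 1 stays in place.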